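Dropping the Bromo Group from Compound 1

This account rests on a few compounds, and the source may have more. Where it says the series, first, only, none or still open, it means among the compounds named here.

Measured so far:
Compound 1, `CC(C)CN(NC(=O)C1CCC2(CC1)OOC1(OO2)C2CC3CC(C2)CC1C3)c1nc(C#N)ncc1Br`, in an ADME assay on NIH3T3 cells (Mus musculus) for cytotoxicity (a higher number here means that more compound is tolerated, a lower number that less compound is tolerated), gives 8000 nM.
Compound 2, `CC(C)CN(NC(=O)C1CCC(=O)CC1)c1nc(C#N)ncc1Br`, in this assay reaches only a limit of the assay, not a number, namely > 100000 nM.

For the measured compounds named here, compound 1 therefore holds the only numerical reading in this assay. The result for compound 2 sits at the limit of > 100000 nM in this assay, at which 1 of the 2 values shown sits, and a limit says nothing about how far beyond it the true value lies.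

Compound 3, `CC(C)CN(NC(=O)C1CCC2(CC1)OOC1(OO2)C2CC3CC(C2)CC1C3)c1ccnc(C#N)n1`, differs from compound 1 in one place: hydrogen in place of bromo on an aromatic carbon. Going by the values given here, no step between two measured compounds is available here, so the size of this change has no precedent in these data. In this assay the step is expected to be small, within or just beyond the usual scatter, and if anything toward more compound being tolerated: a 1.5-fold higher number from compound 1 to compound 3 (0.18 log units; within the scatter). Compound 3 is accordingly estimated at 12000 nM, with an expected range from 4000 nM to 40000 nM.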

Compound 3, half-maximal cytotoxic concentration: 900 nM
Compound 3: the middle estimate sits 13-fold (1.12 log units) above what was measured; the whole stated range lies above it.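

In this assay, for the compounds shown here, the change gives an 8.9-fold lower number from compound 1 to compound 3 (0.95 log units; beyond the scatter) and so provides the first measured step at this position on the ring. It shows that this place is not neutral here: going from 5-bromo-2-cyanopyrimidin-4-yl to 2-cyanopyrimidin-4-yl, with nothing else altered, means that less compound is tolerated, and by more than repeat measurements would scatter. Nothing among the data shown accounts for why swapping bromo for hydrogen moves the number this way.

This single pair cannot tell whether bromo itself matters or whether another group in the same place, such as chloro or methyl, would keep the number of compound 1. It also leaves open whether the same swap would give a step of similar size on a different core.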